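A few compounds are considered here, and "the series" means these few. Any claim that something is new, unique, unknown or untested is made for them only; others in the source may bear on it.

Compound 1 `CC(C)(C)n1ncc(OCc2nnc(-c3ccc(Cl)cc3Cl)o2)c(Cl)c1=O` gives 3.52 in a physicochemical assay for lipophilicity; a higher number here means a more lipophilic compound, a lower number a more polar compound.
Compound 2 `CC(C)(C)n1ncc(OCc2nnc(-c3ccccc3F)o2)c(Cl)c1=O` gives 2.89 in this assay.
Compound 3 `CC(C)(C)n1ncc(OCc2nnc(-c3ccccc3Cl)o2)c(Cl)c1=O` gives 3.19 in this assay.

Among these three numbers compound 3 stands second highest. Compound 1 lies above it by a number 0.33 log units lower from compound 1 to compound 3 (beyond the scatter), a gap beyond the scatter, while compound 2 is its nearest neighbour, the step of a number 0.30 log units higher from compound 2 to compound 3 (within the scatter) lying within the scatter, so those two cannot be told apart.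

Compound 4 `CC(C)(C)n1ncc(OCc2nnc(-c3ccc(F)cc3)o2)c(Cl)c1=O` has not yet been measured in this assay. Compared with compound 3 it carries a (4-fluorophenyl in place of 2-chlorophenyl on an aromatic carbon). Among the compounds with values here, two measured steps bear on this change. The exchange of fluoro for chloro on the shared core, a number 0.30 log units higher from compound 2 to compound 3 (within the scatter), stayed within the scatter; the larger rebuild a number 0.63 log units lower from compound 1 to compound 2 (beyond the scatter) was modest and beyond it. Within the data shown here, compound 4 swaps the chloro for a fluoro and also places the halogen elsewhere on the phenyl ring, and no measured pair shows that move alone. A small step downward in this assay is therefore expected, about the size of the fluoro-for-chloro exchange, possibly none beyond the scatter. For compound 4 the estimated value in this assay is 2.9, with a range from 2.6 to 3.3, meaning an expected step of a number 0.29 log units lower from compound 3 to compound 4 (within the scatter).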

Compound 4, partition coefficient: 2.69
Compound 4: the middle estimate sits 0.21 log units above what was measured; the measured number falls inside the stated range.
By their numbers in this assay, from the lowest: compounds 4, 2 and 3 (each within the scatter of the next, the first and the last beyond it); then compound 1.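

Placing a 4-fluorophenyl on the shared core in place of the 2-chlorophenyl gives a number 0.50 log units lower from compound 3 to compound 4 (beyond the scatter) in this assay and so separates two singly halogenated phenyl groups at this position, which the exchange of fluoro for chloro alone had not done. Keeping the fluoro and changing only its place, 4-fluorophenyl for 2-fluorophenyl, gives a number 0.20 log units lower from compound 2 to compound 4 (within the scatter) and leaves those two compounds indistinguishable. The change from 2,4-dichlorophenyl to 4-fluorophenyl spans the widest gap so far, a number 0.83 log units lower from compound 1 to compound 4 (beyond the scatter) and no measurement shown here explains any of these steps.

A 4-chlorophenyl at this position would show whether the 2-chlorophenyl result depends on the halogen or on its place on the ring. As far as these compounds go, how a phenyl ring carrying an amine or a carboxylic acid would behave here also remains open.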